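The compounds below may be only part of what the source reports. "The series", "measured", "known", "first", "only" and "open" are said of these compounds alone.

Toxicity to cells is followed here through an ADME assay on Vero cells (Chlorocebus sabaeus) for cytotoxicity; a lower number here means that less compound is tolerated, a higher number that more compound is tolerated. Compound 1 `Cn1cnc2c(N[C@H]3C4C=CC(CC4)[C@@H]3C(=O)O)nc(-c3c[nH]c4ncc(F)cc34)nc21` gives > 100000 nM, which is a limit of the assay and not an exact number. Compound 2 `Cc1csc2c(N[C@H]3C4C=CC(CC4)[C@@H]3C(=O)O)nc(-c3c[nH]c4ncc(F)cc34)nc12` gives > 100000 nM, and this too is only a limit. Within the data shown here, the position of compound 2 is therefore known only from one side, and no measured step shows how any single change acts on this read-out.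

Compound 3 `O=C(O)[C@H]1C2C=CC(CC2)[C@@H]1Nc1nc(-c2c[nH]c3ncc(F)cc23)nc2ccsc12` differs from compound 2 in one place: hydrogen in place of methyl on an aromatic carbon. With nothing measured to suggest a shift, no change beyond the usual scatter is expected in this assay, in either direction. The expected step is a number no higher from compound 2 to compound 3 (the limit leaves the size open). For compound 3 the estimated value is 100000 nM, with an expected range from 40000 nM to 200000 nM.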

Compound 3, half-maximal cytotoxic concentration: 74900 nM
Compound 3: middle estimate off by 1.3-fold (0.13 log units), on the high side; measured number inside the range.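

Among the three compounds shown, compound 3 is the only one with an exact number in this assay, so the aromatic carbon two ring bonds from the ring sulfur now has a reading that is not a limit. Putting hydrogen in place of methyl there gives an at least 1.3-fold lower number from compound 2 to compound 3 (0.12 log units; that floor lies within the scatter), which shows no change beyond the scatter but does not rule out a larger one. The true size of the step stays unknown because its starting point is only a limit: the limit of > 100000 nM in this assay, at which 2 of the 3 values shown sit.

Still open, from the compounds shown here alone, is how a different group on this carbon, such as a chlorine atom, a methoxy group or an amine, would act on this read-out. Also open, going by these compounds, is whether the same exchange of methyl for hydrogen would give a measurable step between two compounds that both have exact numbers.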